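The source may report more compounds than this note shows. Statements on the series, on what has been measured and on what is new or still open speak of the compounds shown alone.

Compound 3 `CN(C)/N=C1/CN(CC(=O)Nc2cccc(-c3cnn(C)c3)c2)C(=O)C(Cc2c(F)cccc2Cl)CN1` gives 940 nM in an assay on isolated protein for inhibition of kallikrein-7 (Homo sapiens), read by fluorescence, with stated times of 10 min and 30 min (a higher number here means a weaker inhibitor, a lower number a stronger inhibitor), the lower of the two single numbers shown. Compound 1 `Cc1cccc(C)c1CC1CN/C(=N\N(C)C)CN(CC(=O)Nc2cccc(-c3cnn(C)c3)c2)C1=O` gives 5200 nM in this assay, and the step of a 5.5-fold lower number from compound 1 to compound 3 (0.74 log units; beyond the scatter) lies beyond the scatter. Compound 2 `CN(C)/N=C1/CN(CC(=O)Nc2cccc(-c3cnn(C)c3)c2)C(=O)C(Cc2c(Cl)cccc2Cl)CN1` gives 790 nM; > 30000 nM; 380 nM (3 entries) in this assay, several entries that do not agree with one another. Compound 4 `CN(C)/N=C1/CN(CC(=O)Nc2cccc(-c3cnn(C)c3)c2)C(=O)C(Cc2ccccc2Cl)CN1` differs from compound 3 by hydrogen in place of fluoro on an aromatic carbon. Within the data shown here, no measured step removes a single halogen in this way; the only measured step swaps the whole aryl group, so it gives little guidance here. The change from compound 3 to compound 4 is therefore expected to stay within the scatter, a 1.5-fold higher number from compound 3 to compound 4 (0.17 log units; within the scatter). Compound 4 is estimated at 1400 nM, with a range from 500 nM to 4000 nM.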

Compound 4, half-maximal inhibitory concentration: 2500 nM
Compound 4: the middle estimate sits 1.8-fold (0.25 log units) below what was measured, within the range that was stated.
By their numbers in this assay, from the lowest: compound 3; then compound 4; then compound 1.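

In this assay, hydrogen in place of fluoro gives a 2.7-fold higher number from compound 3 to compound 4 (0.42 log units; beyond the scatter) and so shows that this single atom on the aromatic ring changes the number, which the earlier swap of the whole aryl group could not separate. Without that fluoro, the ring still gives a 2.1-fold lower number from compound 1 to compound 4 (0.32 log units; beyond the scatter) so the fluoro does not account for the whole difference from the 2,6-dimethylphenyl compound.

On these data alone, whether a methoxy group or an amine on that aromatic carbon would lower the number further remains open. A second chloro there gives no firm comparison, since the entries of compound 2 disagree and one is a limit of the assay: the several entries of compound 2 in this assay, 790 nM; > 30000 nM; 380 nM (3 entries)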